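The source may report more compounds than this note shows. Statements on the series, on what has been measured and on what is new or still open speak of the compounds shown alone.

Of the compounds shown here, two have so far been measured in a functional assay on CHO-K1 cells for antagonist activity at prostaglandin E2 receptor EP1 subtype (Homo sapiens), read by FLIPR and calcium flux; on this read-out lower numbers stand for stronger inhibition and higher numbers for weaker inhibition. Compound 1 `CCc1ccccc1N(CC(=O)NCc1ccc(OC)c(OC)c1)S(=O)(=O)c1ccc(C)cc1` gives 282 nM in this assay. Compound 2 `CCc1ccccc1N(CC(=O)NCc1cccc(OC(F)(F)F)c1)S(=O)(=O)c1ccc(C)cc1` gives 427 nM. Compound 1 holds the lower of the two numbers, but the step of a 1.5-fold higher number from compound 1 to compound 2 (0.18 log units; within the scatter) stays within the scatter, so the two cannot be told apart on these data.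

Compound 3 `CCc1ccccc1N(CC(=O)NCc1ccccc1F)S(=O)(=O)c1ccc(C)cc1` has not yet been measured. It differs from compound 1 in one place: 2-fluorophenyl in place of 3,4-dimethoxyphenyl on a saturated chain carbon bound to an amide-type nitrogen. For the measured compounds named here, the only measured step that bears on this change is the one in which the same 3,4-dimethoxyphenyl left the same position, a 1.5-fold higher number from compound 1 to compound 2 (0.18 log units; within the scatter), and that step did not move beyond the scatter. With nothing more to go on, compound 3 is expected to land close to compound 1, with at most a small drift toward a higher number.

The estimate for compound 3 in this assay is 400 nM, with a range from 180 nM to 900 nM. That estimate means a step of a 1.4-fold higher number from compound 1 to compound 3 (0.15 log units; within the scatter), which is expected to remain within the scatter.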

Compound 3, inhibition constant: 135 nM
Compound 3: the middle estimate sits 3.0-fold (0.47 log units) above what was measured; the whole stated range lies above it.
By their numbers in this assay, from the lowest: compound 3; then compounds 1 and 2 (each within the scatter of the next).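

In this assay, the group on the saturated chain carbon bound to an amide-type nitrogen now proves able to shift the read-out beyond the scatter, which the earlier pair of compounds could not show: the change to 2-fluorophenyl gives a 2.1-fold lower number from compound 1 to compound 3 (0.32 log units; beyond the scatter) and, against the other measured group, a 3.2-fold lower number from compound 2 to compound 3 (0.50 log units; beyond the scatter). Compound 3 therefore holds the lowest number of the three with the smaller group, with fewer heavy atoms than the 3,4-dimethoxyphenyl of compound 1, and with no hydrogen-bond acceptors on that group, so the two acceptors of the 3,4-dimethoxyphenyl are not required to reach this level of inhibition. Nothing available explains why the number falls with this change.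

On these data alone, each of the three compounds carries a different substituted ring, so the contribution of the fluorine cannot be separated from the loss of the other substituents, and how an unsubstituted phenyl, a 2-chlorophenyl or a 2-methoxyphenyl would stand at this position remains open. As far as these compounds go, it is equally open whether the step to 2-fluorophenyl would hold if the core of compound 1 carried a pyridine ring in place of the ethyl-bearing phenyl.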